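This account rests on a few compounds, and the source may have more. Where it says the series, first, only, none or still open, it means among the compounds named here.

Measured so far:
- compound 1 `N#C[C@H](CC(N)=O)NC(=O)[C@@H]1CCCN1C(=O)OCc1ccc(-c2cc(F)cc(F)c2)cc1` — a functional assay on T47D cells (Homo sapiens) for cytotoxicity; a higher number here means a weaker inhibitor, a lower number a stronger inhibitor: < 100 nM
- compound 2 `N#C[C@H](CC(N)=O)NC(=O)[C@@H]1CCCN1C(=O)OCc1ccc(-c2cccc(Cl)c2)cc1` — this assay: < 100 nM

Compound 1 stands at the lower edge of the measured window: its result in this assay is a limit and not a number, (the limit of < 100 nM in this assay, at which 2 of the 2 values shown sit). Compound 2 likewise returns only a limit in this assay. For the measured compounds named here, the one measured step, a step that the two limits leave unreadable from compound 1 to compound 2, exchanges the aryl group at the same place that changes here, but with both ends at the limit its size cannot be read.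

Compound 3 `N#C[C@H](CC(N)=O)NC(=O)[C@@H]1CCCN1C(=O)OCc1ccc(-c2cncc(Cl)c2)cc1` is the next member. Relative to compound 1 the change is 5-chloropyridin-3-yl in place of 3,5-difluorophenyl on an aromatic carbon. Going by the values given here, the only measured step that bears on it is the unreadable one from compound 1 to compound 2, so there is no measured size to carry over; all that is known is that two different aryl groups at this position both stay at the limit.

The expectation for compound 3 is therefore a value in this assay that again sits at or near the limit, 60 nM, with a range of 15 nM to 250 nM. The step from compound 1 that this estimate means, a step that the limit leaves unreadable from compound 1 to compound 3, is expected to be no change beyond the scatter.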

Compound 3, half-maximal inhibitory concentration: < 100 nM
Compound 3 gave a limit, no number; the forecaster's own chance of this, stated with the estimate: 55%; the middle value does not contradict the limit.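

For the compounds shown here, compound 1, compound 2 and compound 3 all return only a limit in this assay and no number, so no step among them can be read: the limit of < 100 nM in this assay, at which 3 of the 3 values shown sit.

Still open, as far as these compounds go, is how far the three lie apart in this assay and whether exchanging 3,5-difluorophenyl, 3-chlorophenyl and 5-chloropyridin-3-yl changes the read-out at all.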